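Chlorine on the pendant phenyl: a step from compound 3

The compounds below may be only part of what the source reports. "The series", "measured", "known", "first", "only" and "open" are said of these compounds alone.

Measured compounds:
Compound 1 `CCOC(=O)c1cc(-c2ccc(OC(=O)NC3CCCCC3)cc2)n(-c2ccc(Cl)cc2)n1` – in an assay on isolated protein for inhibition of Fatty-acid amide hydrolase 1 (Homo sapiens), read by fluorescence, with a stated time of 30 min (on this read-out higher numbers stand for weaker inhibition and lower numbers for stronger inhibition), compound 1 gives 281 nM.
Compound 2 `Cn1nc(C(N)=O)cc1-c1ccc(OC(=O)NC2CCCCC2)cc1` – in this assay compound 2 gives 209 nM.
Compound 3 `NC(=O)c1cc(-c2ccc(OC(=O)NC3CCCCC3)cc2)n(-c2ccccc2)n1` – in this assay compound 3 gives 71 nM.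

Compound 3 stands at the lowest of the three numbers. Among the compounds with values here, its nearest neighbour is compound 2, and the one step between compounds that differ in a single place is a 2.9-fold lower number from compound 2 to compound 3 (0.47 log units; beyond the scatter), which puts phenyl in place of methyl on an aromatic nitrogen. Compound 1 sits furthest from compound 3, but it differs from compound 3 in two places at once, so its value says nothing on its own about either change.

Compound 4 `NC(=O)c1cc(-c2ccc(OC(=O)NC3CCCCC3)cc2)n(-c2ccc(Cl)cc2)n1` differs from compound 3 by chloro in place of hydrogen on an aromatic carbon, the chloro sitting on an aromatic carbon of a six-membered aromatic ring of carbon only, para to a large group. No measured step among these three compounds isolates this change; compound 1 carries the same chloro but also an ethyl ester in place of the amide. The step from compound 2 to compound 3 concerns a different part of the molecule and does not bear on it. Within the data shown here, with no direct precedent, the step of a 1.2-fold higher number from compound 3 to compound 4 (0.08 log units; within the scatter) is expected to stay within the scatter in this assay. Compound 4 is therefore estimated at 85 nM, in the range 30 nM to 250 nM.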

Compound 4, half-maximal inhibitory concentration: 172 nM
Beside the measured number, compound 4's estimate is 2.0-fold (0.31 log units) below it; measured number inside the range.
By their numbers in this assay, from the lowest: compound 3; then compounds 4, 2 and 1 (each within the scatter of the next).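

In this assay, within the data shown here, the chloro on the pendant phenyl is the first change at this position that can be read alone, and phenyl to 4-chlorophenyl gives a modest loss (a 2.4-fold higher number from compound 3 to compound 4 (0.38 log units; beyond the scatter)). It also changes how the neighbouring steps read: phenyl in place of methyl on the aromatic nitrogen gave a step beyond the scatter (a 2.9-fold lower number from compound 2 to compound 3 (0.47 log units; beyond the scatter)), whereas 4-chlorophenyl in place of methyl stays within it (a 1.2-fold lower number from compound 2 to compound 4 (0.08 log units; within the scatter)), and amino in place of ethoxy on the carbonyl carbon, with the 4-chlorophenyl present, also stays within it (a 1.6-fold lower number from compound 1 to compound 4 (0.21 log units; within the scatter)). So among these compounds, the advantage of compound 3 depends on the hydrogen at this place, and nothing available explains why the chloro has this effect.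

From the compounds shown here alone, whether fluoro or methoxy in place of the chloro would give a number closer to that of compound 3 or that of compound 4 remains open. So does how a carboxylic acid, with a hydroxyl in place of the amino on that carbonyl carbon, would read in this assay.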